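Second chloro on the aryl ring of a pyrrolidine-bearing core

A few compounds are considered here, and "the series" means these few. Any claim that something is new, unique, unknown or untested is made for them only; others in the source may bear on it.

Of the compounds shown here, two sharing one core have been measured in a functional assay on BeWo cells (Homo sapiens) for cytotoxicity, read by MTT assay, with a stated time of 72 h; on this read-out higher numbers stand for weaker inhibition and lower numbers for stronger inhibition. Compound 1 `CC(C)(C)c1nnc2nnc(N3CCCC3)nn12` carries a tert-butyl group and gives 12500 nM. Compound 2 `Clc1ccccc1-c1nnc2nnc(N3CCCC3)nn12` carries a 2-chlorophenyl group in its place and gives 2990 nM, the lower of the two numbers; the step of a 4.2-fold lower number from compound 1 to compound 2 (0.62 log units; beyond the scatter) is the only one recorded. Compound 3 `Clc1ccc(-c2nnc3nnc(N4CCCC4)nn23)c(Cl)c1` differs from compound 2 by chloro in place of hydrogen on an aromatic carbon. Among the measured compounds shown here, no measured step bears directly on this change: the one step known concerns the exchange of tert-butyl for the aryl group, not a substituent on the aryl ring. Without a precedent, a change close to the scatter is the most defensible expectation, leaning slightly toward a lower number, so the step of a 1.5-fold lower number from compound 2 to compound 3 (0.17 log units; within the scatter) is estimated. Compound 3 is therefore expected to give about 2000 nM in this assay , within a range from 700 nM to 6000 nM.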

Compound 3, half-maximal inhibitory concentration: 8060 nM
For compound 3 the middle estimate is 4.0-fold (0.61 log units) below the measured one, and the stated range ends below it.
By their numbers in this assay, from the lowest: compound 2; then compounds 3 and 1 (each within the scatter of the next).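

In this assay the added chloro, meta to a chloro group and para to a large group, gives a 2.7-fold higher number from compound 2 to compound 3 (0.43 log units; beyond the scatter), so this position on the aryl ring does respond to substitution, and a single heavy atom moves the number beyond the scatter toward weaker inhibition. Among the compounds shown here, this is the first recorded step on the aryl ring itself, as the earlier step concerned only the exchange of tert-butyl for the aryl group. No evidence is available on why the number rises.

The compounds shown leave open whether this rise is specific to chloro, as no fluoro, methyl, methoxy or amine stands at this position. They also leave open how this chloro would behave on a phenyl ring without the first chloro.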